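The source may hold more compounds than are shown below. What is called first, only, known or untested is meant among the compounds shown, and "the series" means these compounds.

Compound 1 `O=C(NCCCN1CCN(c2ccccn2)CC1)c1cccc2ccccc12` and compound 2 `O=C(NCCCN1CCN(c2cccc(Cl)c2Cl)CC1)c1cccc2ccccc12` share a core and differ only in the group on the ring amine nitrogen. In an assay on HEK293 cells for inhibition of sodium-dependent dopamine transporter (Homo sapiens), read by scintillation counting (a lower number here means a stronger inhibitor, a higher number a weaker inhibitor), compound 1 gives a value that is a limit of the assay, > 10000 nM. In this assay compound 2 likewise gives only a limit, > 10000 nM. The step that the two limits leave unreadable from compound 1 to compound 2 therefore cannot be read, because of the limit of > 10000 nM in this assay, at which 2 of the 2 values shown sit. Compound 3 `O=C(NCCCN1CCN(c2cccc(Cl)c2Cl)CC1)c1ccc2ccccc2n1` differs from compound 2 by quinolin-2-yl in place of naphthalen-1-yl on a carbonyl carbon. Among the compounds with values here, no measured step bears on that change, and compound 2 stands only at a limit. Compound 3 is expected to stay near that limit, with a step that the limit leaves unreadable from compound 2 to compound 3 estimated, giving an estimated 15000 nM within 4000 nM to 60000 nM.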

Compound 3, half-maximal inhibitory concentration: > 10000 nM
Compound 3: no number, only a limit; the forecaster's own chance of this, stated with the estimate: 75%; the middle value lies beyond the limit too.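

In this assay compound 3 gives only a limit of the assay, > 10000 nM and no number. Within the data shown here, compound 2 also stands at a limit, so no step between them can be read. As far as these compounds go, what the change from naphthalen-1-yl to quinolin-2-yl does to the values in this assay stays open.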